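The source may hold more compounds than are shown below. What is called first, only, known or untested is meant among the compounds shown, and "the series" means these compounds.

Compound 1 `COc1ccc(/C=C/C(=O)c2ccccc2-c2ccc(F)cc2)cc1`: 53 nM
Compound 2 `Cc1ccc(/C=C/C(=O)c2ccccc2-c2ccc(F)cc2)o1`: 14000 nM

In a functional assay on CNE-2 cells (Homo sapiens) for antiproliferative activity, read by sulforhodamine B assay, with a stated time of 48 h (on this read-out higher numbers stand for weaker inhibition and lower numbers for stronger inhibition), compound 2 gives 14000 nM as the higher of the two numbers, so it is the weaker inhibitor of the pair. Compound 3 `O=C(/C=C/c1cccs1)c1ccccc1-c1ccc(F)cc1` is the next to be read. The change is as follows: thiophen-2-yl in place of 5-methylfuran-2-yl on a double-bonded chain carbon bound to a double-bonded chain carbon.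

Among the measured compounds shown here, only one measured step bears on this place, a 260-fold higher number from compound 1 to compound 2 (2.42 log units; beyond the scatter). That step is large and beyond the scatter, but it replaced 4-methoxyphenyl. Here, one five-membered aromatic ring with 1 hetero atom replaces another, and no measured step compares two such groups. The size of the earlier step therefore carries over poorly, and a much smaller change is expected. For the measured compounds named here, with only two measured compounds, the direction is uncertain. A modest move towards a lower number is favoured, since compound 2 at 14000 nM sits at the high end of the numbers seen so far.

The expected change is a 2.3-fold lower number from compound 2 to compound 3 (0.37 log units; beyond the scatter) in this assay and remains a wide estimate. For compound 3 the estimated value is 6000 nM within an expected range of 1000 nM to 30000 nM in this series.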

Compound 3, half-maximal inhibitory concentration: 5900 nM
Estimate against measurement, compound 3: 1.0-fold (0.01 log units) above; the range from low to high includes it.
By their numbers in this assay, from the lowest: compound 1; then compound 3; then compound 2.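

In this assay, the exchange of one five-membered aromatic ring with 1 hetero atom for another, on a double-bonded chain carbon bound to a double-bonded chain carbon, gives a 2.4-fold lower number from compound 2 to compound 3 (0.38 log units; beyond the scatter) and is modest although beyond the scatter. Thiophen-2-yl closes little of the gap to 4-methoxyphenyl: the series still shows a 110-fold higher number from compound 1 to compound 3 (2.05 log units; beyond the scatter) and that step remains large. Among the three compounds, the choice between the two five-membered rings therefore moves the number far less than either replacement of 4-methoxyphenyl, and no measured information offers a reason for either step.

The compounds shown do not separate the exchange of oxygen for sulfur from the loss of the methyl group, since 5-methylfuran-2-yl and thiophen-2-yl differ in both, and an unsubstituted furan-2-yl at this place would tell the two apart. Going by these compounds, it also stays open whether the low number of compound 1 rests on the phenyl ring or on its methoxy group, a question that an unsubstituted phenyl or a 4-aminophenyl group at this place would address.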